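Adding trifluoromethyl to the lowest of three compounds

A few compounds are considered here, and "the series" means these few. Any claim that something is new, unique, unknown or untested is made for them only; others in the source may bear on it.

Compound 1 `O=C(CCCCCNc1c(Nc2ccccc2)c(=O)c1=O)NO` gives 2200000 nM
Compound 2 `O=C(CCCCNc1c(Nc2ccccc2)c(=O)c1=O)NO` gives 32000000 nM
Compound 3 `Cc1ccccc1Nc1c(NCCCCCC(=O)NO)c(=O)c1=O` gives 12000000 nM

All three numbers come from a physicochemical assay for solubility, with a stated time of 24 h, tested at 30 mg/mL (a lower number here means a less soluble compound, a higher number a more soluble compound), and compound 1 holds the lowest of them. The next compound to be measured is compound 4 `O=C(CCCCCNc1c(Nc2ccc(C(F)(F)F)cc2)c(=O)c1=O)NO` which differs from compound 1 as follows: trifluoromethyl in place of hydrogen on an aromatic carbon so it carries trifluoromethyl in place of hydrogen on an aromatic carbon.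

Among the measured compounds shown here, two measured steps bear on this change. The closest in kind puts methyl in place of hydrogen on an aromatic carbon, and it gave a 5.5-fold higher number from compound 1 to compound 3 (0.74 log units; beyond the scatter) as a modest rise. For the measured compounds named here, no measured compound carries trifluoromethyl, however, so that rise cannot simply be carried over. The other step alters the chain, with hydroxycarbamoyl in place of (hydroxycarbamoyl)methyl, and it gave a 15-fold higher number from compound 1 to compound 2 (1.16 log units; beyond the scatter) as a large rise from trimming a group. Compound 3 goes against any simple pattern in which a bigger group means a lower number. The direction is therefore uncertain, with a modest drop the slightly more likely outcome. The expected change is a 2.8-fold lower number from compound 1 to compound 4 (0.44 log units; beyond the scatter) in this estimate. Compound 4 is expected near 800000 nM with an estimated range from 150000 nM to 4000000 nM in this assay as the assay to watch.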

Compound 4, solubility: 4700000 nM
Beside the measured number, compound 4's estimate is 5.9-fold (0.77 log units) below it; the measured number lies above the stated range.
By their numbers in this assay, from the lowest: compound 1; then compound 4; then compound 3; then compound 2.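

In this assay, putting trifluoromethyl, with its 4 heavy atoms, on an aromatic carbon para to a large group gives a 2.1-fold higher number from compound 1 to compound 4 (0.33 log units; beyond the scatter), so this change on the aromatic ring also raises the number rather than lowering it. Among the compounds shown here, until now, the only evidence for a hydrogen replaced on this ring was the methyl change, a 5.5-fold higher number from compound 1 to compound 3 (0.74 log units; beyond the scatter), and a second, different group now moves the number in the same direction, though compound 3 and compound 4 carry their groups at different places on the ring. No measurement presented here accounts for the rise seen with either group.

As far as these compounds go, it remains open whether the number would also rise with an amine, a carboxylic acid or a methoxy group at the same place, para to a large group, which would show whether the rise extends beyond these two groups. It is also unclear how trifluoromethyl would behave on the shorter chain of compound 2, which already gives the highest number of the four compounds.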